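Amide aryl variation and cytotoxicity: working notes

The source may hold more compounds than are shown below. What is called first, only, known or untested is meant among the compounds shown, and "the series" means these compounds.

Measured so far:
compound 1 `COc1ccc2c(=O)c(/C=C/C(=O)Nc3cc(C)ccc3C)coc2c1`: 1100000 nM
compound 2 `COc1ccc2c(=O)c(/C=C/C(=O)Nc3ccccc3OC)coc2c1`: 1050000 nM

In an ADME assay on HepG2 2.2.15 cells (Homo sapiens) for cytotoxicity, read by MTT assay, with stated times of 48 h and 9 days (on this read-out higher numbers stand for lower toxicity in this test and lower numbers for higher toxicity in this test), compound 2 gives 1050000 nM; compound 1 gives 1100000 nM, and the two stand within the scatter of each other. Compound 3 `COc1ccc2c(=O)c(/C=C/C(=O)Nc3ccccc3C)coc2c1` differs from compound 2 by methyl in place of methoxy on an aromatic carbon. Going by the values given here, the only measured step bearing on this position, a 1.0-fold lower number from compound 1 to compound 2 (0.02 log units; within the scatter), exchanged the whole aryl group on the amide nitrogen and stayed within the scatter, so no movement beyond the scatter is expected here either. The step from compound 2 to compound 3 is estimated at a 1.0-fold higher number from compound 2 to compound 3 (0.01 log units; within the scatter). Compound 3 is expected at 1080000 nM, range 600000 nM to 2000000 nM.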

Compound 3, half-maximal cytotoxic concentration: 59700 nM
For compound 3 the middle estimate is 18-fold (1.26 log units) above the measured one, and the stated range ends above it.
By their numbers in this assay, from the lowest: compound 3; then compounds 2 and 1 (each within the scatter of the next).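

In this assay the aryl group on the amide nitrogen is not a silent position: an 18-fold lower number from compound 2 to compound 3 (1.25 log units; beyond the scatter) comes with methyl in place of methoxy, and an 18-fold lower number from compound 1 to compound 3 (1.27 log units; beyond the scatter) comes with hydrogen in place of methyl. So 2-methylphenyl stands apart from both 2-methoxyphenyl and 2,5-dimethylphenyl, which stay within the scatter of each other, and small single changes on this ring can move the read-out towards higher toxicity in this test. Nothing available explains these steps.

Still open, from the compounds shown here alone, is whether the low number belongs to 2-methylphenyl alone or also comes with chloro or an amine on that aromatic carbon.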